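Swapping Phenyl for Furan on an Inactive Nucleoside Core

The source may report more compounds than this note shows. Statements on the series, on what has been measured and on what is new or still open speak of the compounds shown alone.

Compound 1 `Nc1nc2c(c(-c3ccccc3)cn2[C@@H]2O[C@H](CO)[C@@H](O)[C@H]2O)c(=O)[nH]1` was tested in a functional assay on HL-60 cells (Homo sapiens) for antiproliferative activity, read by XTT assay, with a stated time of 72 h; on this read-out higher numbers stand for weaker inhibition and lower numbers for stronger inhibition. In this assay compound 1 gives no number but only a limit, > 20000 nM. That places compound 1 at the limit of > 20000 nM in this assay, at which 2 of the 3 values shown sit. Two other compounds tell the same story. Compound 2 `Nc1nc(N)c2c(-c3ccoc3)cn([C@@H]3O[C@H](CO)[C@@H](O)[C@H]3O)c2n1` returns only a limit in this assay, > 20000 nM. Compound 3 `Cc1ncnc2c1c(-c1ccoc1)cn2[C@@H]1O[C@H](CO)[C@@H](O)[C@H]1O` also returns only a limit, > 15000 nM, which is the limit of > 15000 nM in this assay, at which 1 of the 3 values shown sits. For the measured compounds named here, because none of the three gives a number, no step between measured compounds can be sized here.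

Compound 4 `Nc1nc2c(c(-c3ccco3)cn2[C@@H]2O[C@H](CO)[C@@H](O)[C@H]2O)c(=O)[nH]1` has not yet been measured. It differs from compound 1 in one place: furan-2-yl in place of phenyl on an aromatic carbon. Every measured compound stays at a limit, and nothing among them suggests that this change would bring a measurable number. The step that the limit leaves unreadable from compound 1 to compound 4 is therefore expected to be none beyond the scatter. Compound 4 is most likely to return a limit as well, and its estimated value in this assay is 30000 nM, with a range from 10000 nM to 100000 nM.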

Compound 4, half-maximal inhibitory concentration: > 20000 nM
Compound 4: only a limit was reported (the forecaster's own chance of this, stated with the estimate: 85%); the middle value is on the limit's open side.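

Compound 1 and compound 4 both end at a limit rather than a number in this assay, so no step can be read for furan-2-yl in place of phenyl. The compounds shown leave open whether any change on the shared core would give a measurable value.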